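Sulfonamide Aryl Swap on a Threonine Amide Scaffold

The source may report more compounds than this note shows. Statements on the series, on what has been measured and on what is new or still open speak of the compounds shown alone.

Measured so far:
Compound 1, `CCCCCCCCCCCCCCCCCCNC(=O)[C@@H](N)[C@@H](C)O`: 27400 nM
Compound 2, `CCCCCCCCCCCCCCCCCCNC(=O)[C@@H](NS(=O)(=O)c1ccc(C)cc1)[C@@H](C)O`: 60100 nM

Among the compounds with values here, in a functional assay on MCF7 cells (Homo sapiens) for cytotoxicity, read by MTT assay, with a stated time of 48 h (a lower number here means a stronger inhibitor, a higher number a weaker inhibitor), compound 2 stands at the higher of the two numbers, with compound 1 the only neighbour and a 2.2-fold higher number from compound 1 to compound 2 (0.34 log units; beyond the scatter); that one step is the whole of what is known for this pair. Compound 3, `CCCCCCCCCCCCCCCCCCNC(=O)[C@@H](NS(=O)(=O)c1ccc2ccccc2c1)[C@@H](C)O`, differs from compound 2 by naphthalen-2-yl in place of 4-methylphenyl on a sulfonyl sulfur. Within the data shown here, no measured step replaces one aryl group by another on the sulfonyl sulfur, so the single step from compound 1 to compound 2 is the only guide, and it shows that placing an aryl sulfonyl on the amine changed the number only modestly. For compound 3 a step of about a 1.1-fold lower number from compound 2 to compound 3 (0.04 log units; within the scatter) is expected, that is, no change beyond the scatter. Compound 3 is therefore estimated at 55000 nM in this assay, with a range from 20000 nM to 150000 nM.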

Compound 3, half-maximal inhibitory concentration: 27800 nM
Compound 3: the middle estimate sits 2.0-fold (0.30 log units) above what was measured; the range from low to high includes it.
By their numbers in this assay, from the lowest: compounds 1 and 3 (each within the scatter of the next); then compound 2.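

In this assay the choice of aryl group on the sulfonyl sulfur makes a measurable difference: swapping 4-methylphenyl for naphthalen-2-yl gives a modest change (a 2.2-fold lower number from compound 2 to compound 3 (0.33 log units; beyond the scatter)) that lies beyond the scatter. The position therefore responds to which aryl group it carries, not only to whether a sulfonyl is present, and compound 3 (27800 nM) lies within the scatter of compound 1 (27400 nM), which keeps the free amine. Nothing available gives a reason for this step.

Two compounds with different aryl groups cannot show whether a plain phenyl or a thiophene ring on the sulfonyl sulfur would fall nearer compound 2 or compound 3. As far as these compounds go, how a methyl group there, or a shorter chain on the amide nitrogen, would shift the number also remains open.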